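Removing the carboxy from compound 3

The compounds below may be only part of what the source reports. "The series", "measured", "known", "first", "only" and "open" are said of these compounds alone.

Measured in a functional assay (aorta) for antagonist activity, with Oryctolagus cuniculus as the target; a higher number here means a weaker inhibitor, a lower number a stronger inhibitor:
- compound 1 `CCCSC1=Nc2ccccc2S(=O)(=O)N1Cc1ccc(-c2ccccc2C(=O)O)cc1` gives 1200 nM
- compound 2 `CCSC1=NS(=O)(=O)c2cc(C)cnc2N1Cc1ccc(-c2ccccc2-c2nn[nH]n2)cc1` gives 0.6 nM
- compound 3 `CCCSC1=NS(=O)(=O)c2ccc(C(=O)O)cc2N1Cc1ccc(-c2ccccc2-c2nn[nH]n2)cc1` gives 0.08 nM

Among these three, compound 3 has the lowest number and so is the strongest inhibitor in this assay. Its gaps to compound 2 and to compound 1 both lie beyond the scatter, and the gap to compound 1 is by far the larger.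

The next compound, compound 4 `CCCSC1=NS(=O)(=O)c2ccccc2N1Cc1ccc(-c2ccccc2-c2nn[nH]n2)cc1`, has hydrogen in place of carboxy on an aromatic carbon of compound 3: hydrogen in place of carboxy on an aromatic carbon. Among the measured compounds shown here, no measured pair of compounds isolates this change, so any expectation for it remains loose. The closest guide is compound 2, which has no carboxy on its core and gives 0.6 nM, but it also differs from compound 4 in other places. On that basis, the loss of the carboxy is expected to move the number upward, beyond the scatter, towards the level of compound 2. The expected step is a 10-fold higher number from compound 3 to compound 4 (1.00 log units; beyond the scatter). For compound 4 the estimated value in this assay is 0.8 nM, with an expected range from 0.15 nM to 4 nM.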

Compound 4, antagonist equilibrium constant: 93 nM
The estimate for compound 4 lay 120-fold (2.07 log units) below the measured number; measured number outside the range, above it.
By their numbers in this assay, from the lowest: compound 3; then compound 2; then compound 4; then compound 1.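

In this assay, among the compounds shown here, the pair of compound 3 and compound 4 is the first to differ in one place only, and hydrogen in place of carboxy on the aromatic carbon gives a 1200-fold higher number from compound 3 to compound 4 (3.07 log units; beyond the scatter) with the rest of the structure unchanged. The earlier compounds shown here differ from one another in several places and could not assign any part of their spread to a single group, whereas this pair shows that the carboxy on this carbon, meta to a fused ring and para to a fused ring, carries a large share of the strength of compound 3. Nothing given here accounts for the size of this step.

The compounds shown leave open whether the step belongs to the carboxy itself or whether another group on the same carbon, such as a methyl ester, a primary amide, a hydroxymethyl or a tetrazole, would hold the number near that of compound 3. They also leave open whether adding a carboxy would produce a similar step on a core with an ethylthio chain in place of the propylthio chain.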